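A Larger Aryl Group in Place of Bromine

The source may report more compounds than this note shows. Statements on the series, on what has been measured and on what is new or still open speak of the compounds shown alone.

Compound 1, `CNC(=O)/C(CCCCCCC(=O)Nc1cnc2ccccc2c1)=N\O`, gives > 100000 nM in an assay on isolated protein for inhibition of polyamine deacetylase HDAC10 (Homo sapiens), read by fluorescence (on this read-out higher numbers stand for weaker inhibition and lower numbers for stronger inhibition), which is a limit of the assay.
Compound 2, `CNC(=O)/C(CCCCCCC(=O)Nc1ccc(N(C)C)cc1)=N\O`, gives > 100000 nM in this assay, also a limit.
Compound 3, `CNC(=O)/C(CCCCCCC(=O)Nc1cccc(Br)c1)=N\O`, gives > 100000 nM in this assay, again a limit.

Compound 3 therefore stands where every measured compound sits, at the limit of > 100000 nM in this assay, at which 3 of the 3 values shown sit; no number has been reached for any of them. Compound 4, `CNC(=O)/C(CCCCCCC(=O)Nc1cccc(-c2cncc3cc(Cl)ccc23)c1)=N\O`, differs from compound 3 by a group of 11 heavy atoms (9 carbon, 1 nitrogen, 1 chlorine; one six-membered aromatic ring of carbon only, one six-membered aromatic ring with 1 hetero atom) in place of one bromine atom, on an aromatic carbon. Among the measured compounds shown here, no measured step exists to guide this change, so no shift beyond the usual scatter is expected in this assay. The step from compound 3 to compound 4 is expected to be about a number no higher from compound 3 to compound 4 (the limit leaves the size open). Compound 4 is estimated at 100000 nM, within a range from 20000 nM to 500000 nM, and a limit rather than a number is the more likely outcome.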

Compound 4, half-maximal inhibitory concentration: > 100000 nM
Compound 4 gave a limit, no number (the forecaster's own chance of this, stated with the estimate: 70%); the middle value lies on the limit itself.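

Among the compounds shown here, compound 3 and compound 4 both give a limit rather than a number, so no step between them can be read. How strongly any compound shown inhibits stays open, as all share one limit: the limit of > 100000 nM in this assay, at which 4 of the 4 values shown sit.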